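The source may report more compounds than this note shows. Statements on the series, on what has been measured and on what is new or still open speak of the compounds shown alone.

Series notes on the boron-containing cinnamoyl compounds. In a toxicity assay on WI-38 cells (Homo sapiens) for cytotoxicity, read by MTT assay, with a stated time of 48 h (a higher number here means a weaker inhibitor, a lower number a stronger inhibitor), compound 1 `O=C(/C=C/c1ccc2c(c1)B(O)OC2)c1ccc(-c2ccccc2)cc1` gives 18300 nM. Compound 2 `O=C(/C=C/c1ccc2c(c1)B(O)OC2)c1ccc(F)cc1`, in this assay, gives 7600 nM. For the measured compounds named here, the only step measured so far is a 2.4-fold lower number from compound 1 to compound 2 (0.38 log units; beyond the scatter), which exchanges the phenyl substituent on the carbonyl-bound ring for fluoro. On the numbers shown, compound 2 stands lowest of the two, with compound 1 the nearest neighbour and the only other point.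

Compound 3 `O=C(/C=C/c1ccc2c(c1)B(O)OC2)c1cccc(O)c1` has not yet been measured in this assay. Its change from compound 2 is 3-hydroxyphenyl in place of 4-fluorophenyl on a carbonyl carbon. Going by the values given here, no measured step addresses a hydroxyl group on this ring, nor a move of the substituent from one ring position to another; the single step on record shows that swapping one substituent for another on this ring shifted the number only modestly. Among the compounds with values here, that is the only guide. A step of about the same size or smaller, in either direction, is expected in this assay, most likely not beyond the scatter. The expected step is a 1.2-fold higher number from compound 2 to compound 3 (0.07 log units; within the scatter). Compound 3 is therefore estimated at 9000 nM, with a range from 3000 nM to 30000 nM.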

Compound 3, half-maximal inhibitory concentration: 26400 nM
Compound 3: middle estimate off by 2.9-fold (0.47 log units), on the low side, within the range that was stated.
By their numbers in this assay, from the lowest: compound 2; then compounds 1 and 3 (each within the scatter of the next).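

In this assay, the group on the carbonyl carbon proves sensitive to more than the exchange of one para-free substituent for another: a 3.5-fold higher number from compound 2 to compound 3 (0.54 log units; beyond the scatter), a step of similar order to a 2.4-fold lower number from compound 1 to compound 2 (0.38 log units; beyond the scatter), although the leaving and entering groups are both single aromatic rings with the same heavy-atom count. Compound 2 now holds the lowest number of the three, with both of its measured neighbours beyond the scatter from it, while compounds 1 and 3 lie within the scatter of each other despite their very different groups. Nothing shown gives a reason for this step.

In going from 4-fluorophenyl to 3-hydroxyphenyl, the identity of the substituent and its ring position change together, so the compounds shown cannot say which of the two carries the step. As far as these compounds go, how an amine, a carboxylic acid or a methoxy group on this ring would read in this assay also remains open, as does whether fluoro keeps its standing against such groups.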